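Estimating Compound 3 from Two Measured Analogues

The compounds below may be only part of what the source reports. "The series", "measured", "known", "first", "only" and "open" are said of these compounds alone.

Two compounds share one core and differ only in the group attached through the oxygen on the aromatic ring. Compound 1 `CCOC(=O)C1=C(C)NC(C)=C(C(=O)OCC)C1c1ccc(OCC(=O)NNC(=O)c2ccccc2)cc1` carries a phenyl on the carbonyl carbon, and in a functional assay on the whole organism (strain Wistar) for inhibition, with Rattus norvegicus as the target, read by paw edema, with stated times of 30 min and 1 h, at a dose of 20 mg/kg (a lower number here means less inhibition, a higher number more inhibition at the dose given (going by the name of the read-out)), compound 1 gives 29.5%. Compound 2 `CCOC(=O)C1=C(C)NC(C)=C(C(=O)OCC)C1c1ccc(OCC(=O)NNC(=O)c2sccc2Cl)cc1` carries a 3-chlorothiophen-2-yl in place of that phenyl, and in this assay compound 2 gives 39.7%. That single step is a number 10.2 percentage points higher from compound 1 to compound 2 (beyond the scatter). Compound 2 thus stands highest of the two measured values, with compound 1 beneath it by a gap beyond the scatter.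

Compound 3 `CCOC(=O)C1=C(C)NC(C)=C(C(=O)OCC)C1c1ccc(OCc2nnc(S)o2)cc1` has not yet been measured. Relative to compound 2 the change is a group of 6 heavy atoms (2 carbon, 2 nitrogen, 1 oxygen, 1 sulfur; one five-membered aromatic ring with 3 hetero atoms) in place of a group of 12 heavy atoms (6 carbon, 2 nitrogen, 2 oxygen, 1 sulfur, 1 chlorine; one five-membered aromatic ring with 1 hetero atom), on a saturated chain carbon bound to an oxygen on an aromatic ring. For the measured compounds named here, no measured step bears on a replacement of this kind: the one step known swaps only the aromatic ring on the carbonyl carbon, and it was modest. The expected step of a number 4.7 percentage points lower from compound 2 to compound 3 (within the scatter) is therefore taken as none beyond the scatter, with wide uncertainty. Compound 3 is accordingly estimated at 35% in this assay, within a range from 20% to 50%.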

Compound 3, a percentage reported as inhibition, in the whole organism at one dose (the size of the read-out at that dose, not a potency): 54.5%
Estimate against measurement, compound 3: 19.5 percentage points below; the whole stated range lies below it.
By their numbers in this assay, from the lowest: compound 1; then compound 2; then compound 3.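

In this assay, the replacement on a saturated chain carbon bound to an oxygen on an aromatic ring, 5-sulfanyl-1,3,4-oxadiazol-2-yl in place of benzamidocarbamoyl, gives a number 25 percentage points higher from compound 1 to compound 3 (beyond the scatter), and the same ring in place of the chlorothiophene-bearing group of 12 heavy atoms gives a number 14.8 percentage points higher from compound 2 to compound 3 (beyond the scatter). Where the earlier pair showed only a swap of the aromatic ring on the carbonyl carbon, these steps show that the whole group at this position can be exchanged for a single five-membered aromatic ring with 3 hetero atoms, of 6 heavy atoms, and the inhibition of paw edema at this dose still rises, leaving compound 3 with the highest number of the three. Nothing in the data shown explains why this exchange raises the number.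

The compounds shown leave open whether the rise depends on the sulfanyl group or on the ring that carries it, since no analogue has an amine or a methylsulfanyl group in its place. They also leave open whether a carboxylic acid or a longer chain at the same chain carbon would hold the gain, and how the three compounds compare at other doses.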